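This account rests on a few compounds, and the source may have more. Where it says the series, first, only, none or still open, it means among the compounds named here.

Compound 1 `Cc1cc(C(=O)O)ccc1-c1noc(-c2ccc(C3CCCCC3)cc2)n1` carries a carboxy group directly on its core. In a functional assay on CHO cells for agonist activity at sphingosine 1-phosphate receptor 5 (Homo sapiens), read by GTPgammaS binding (on this read-out lower numbers stand for an effect already at smaller amounts and higher numbers for an effect only at larger amounts of compound), compound 1 gives > 10000 nM, which is a limit of the assay rather than a number; it sits at the limit of > 10000 nM in this assay, at which 1 of the 2 values shown sits. Compound 2 `Cc1cc(CCC(=O)O)ccc1-c1noc(-c2ccc(OC(C)C(F)(F)F)c(C#N)c2)n1`, a different tail on the same core, gives 3.1 nM in this assay. Compound 3 `Cc1cc(CCC(=O)O)ccc1-c1noc(-c2ccc(C3CCCCC3)cc2)n1` differs from compound 1 by 2-carboxyethyl in place of carboxy on an aromatic carbon. Going by the values given here, no measured pair shows this change on its own; compound 2, which also carries the 2-carboxyethyl group, gives 3.1 nM. A large gain in potency is therefore expected, well beyond the usual scatter, an at least 330-fold lower number from compound 1 to compound 3 (2.52 log units; beyond the scatter). Compound 3 is estimated to give 30 nM, with a range from 3 nM to 400 nM.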

Compound 3, half-maximal effective concentration: 591 nM
Beside the measured number, compound 3's estimate is 20-fold (1.29 log units) below it, outside the stated range (above it).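

Putting 2-carboxyethyl in place of carboxy on this aromatic carbon, with the rest of the molecule unchanged, gives an at least 16-fold lower number from compound 1 to compound 3 (1.22 log units; beyond the scatter) in this assay. Going by these compounds alone, this is the first reading of the change on its own, and it shows that the longer acid chain at this position is enough to give a measurable effect. The value of compound 1 is a limit of the assay and not a number, so the step gives only a minimum size: the limit of > 10000 nM in this assay, at which 1 of the 3 values shown sits.

The compounds shown leave open how a longer carboxylic acid chain or an amine would read at this position. They also leave open whether the same change brings a similar gain with other tails.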